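A few compounds are considered here, and "the series" means these few. Any claim that something is new, unique, unknown or untested is made for them only; others in the source may bear on it.

Three compounds have been measured in an assay on H4 cells for inhibition of Fatty-acid amide hydrolase 1 (Homo sapiens); on this read-out higher numbers stand for weaker inhibition and lower numbers for stronger inhibition:
Compound 1, `Cc1nc(-c2ccccc2)c(-c2ccccc2)n1CCCCCC(C)NC(=O)Oc1ccccc1F`, gives 4.2 nM.
Compound 2, `CCC(CCCCCn1c(C)nc(-c2ccccc2)c1-c1ccccc1)NC(=O)Oc1ccccc1F`, gives 30 nM.
Compound 3, `Cc1nc(-c2ccccc2)c(-c2ccccc2)n1CCCCCC(NC(=O)Oc1ccccc1F)C(C)C`, gives 250 nM.

Compound 3 carries the highest number of the three in this assay, that is, the weakest inhibition: a 60-fold higher number from compound 1 to compound 3 (1.77 log units; beyond the scatter) and an 8.3-fold higher number from compound 2 to compound 3 (0.92 log units; beyond the scatter). Compound 4, `Cc1nc(-c2ccccc2)c(-c2ccccc2)n1CCCCCC(NC(=O)Oc1ccccc1F)c1ccccc1`, differs from compound 3 by phenyl in place of isopropyl on a saturated chain carbon bound to an amide-type nitrogen and a saturated chain carbon. The two steps that bear on this change both sit at the same position: moving from methyl through ethyl to isopropyl raised the number each time, so a larger group at this carbon has so far always weakened inhibition. Phenyl is larger still, though of a different shape, so the expectation for compound 4 is a further rise, probably modest, a 2.4-fold higher number from compound 3 to compound 4 (0.38 log units; beyond the scatter). Compound 4 is therefore estimated at 600 nM, with a range from 120 nM to 3000 nM.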

Compound 4, half-maximal inhibitory concentration: 110 nM
For compound 4 the middle estimate is 5.5-fold (0.74 log units) above the measured one; measured number below the stated range.
By their numbers in this assay, from the lowest: compound 1; then compound 2; then compound 4; then compound 3.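

At this carbon, group size alone no longer sets the order: phenyl, the largest group so far, gives a 2.3-fold lower number from compound 3 to compound 4 (0.36 log units; beyond the scatter) and so breaks the rise seen from methyl through ethyl to isopropyl. Phenyl still does not recover the inhibition of the smaller groups, with a 3.7-fold higher number from compound 2 to compound 4 (0.56 log units; beyond the scatter) and a 26-fold higher number from compound 1 to compound 4 (1.42 log units; beyond the scatter). Nothing measured here explains this turn. On these data alone, it remains open whether cyclohexyl, a saturated ring, would follow phenyl or isopropyl. A benzyl group or a substituted phenyl ring at this carbon is also untested in the compounds shown.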